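Changing the amide on a compound at the assay limit

The source may report more compounds than this note shows. Statements on the series, on what has been measured and on what is new or still open speak of the compounds shown alone.

Compound 1 `COC(=O)/C=C/c1cccc(N(Cc2ccc(/C=C/c3cccc(F)c3)cc2)C(=O)C2CCCCC2)c1` gives 86 nM in an assay on isolated protein with Bile acid receptor (Homo sapiens) as the target; on this read-out lower numbers stand for an effect already at smaller amounts and higher numbers for an effect only at larger amounts of compound.
Compound 2 `COC(=O)/C=C/c1cccc(N(Cc2ccc(-c3ccc(F)c(F)c3)cc2)C(=O)C2CCCCC2)c1` gives 72 nM in this assay.
Compound 3 `COC(=O)/C=C/c1cccc(N(Cc2ccc(/C=C/C(=O)N(C)C)cc2)C(=O)C2CCCCC2)c1` gives only a limit, > 1000 nM, in this assay.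

Compound 3 thus stands at the limit of > 1000 nM in this assay, at which 1 of the 3 values shown sits, with no number of its own. Compound 4 `COC(=O)/C=C/c1cccc(N(Cc2ccc(/C=C/C(=O)NC(C)(C)C)cc2)C(=O)C2CCCCC2)c1` differs from it in one place: (tert-butyl)amino in place of dimethylamino on a carbonyl carbon. Among the compounds with values here, no measured step alters the amide itself. The steps reaching compound 3 are an at least 11-fold higher number from compound 1 to compound 3 (1.06 log units; beyond the scatter) and an at least 13-fold higher number from compound 2 to compound 3 (1.14 log units; beyond the scatter), both large rises once a dimethylcarbamoyl replaces a fluorinated aryl. The carbamoyl remains in compound 4, and the change to a (tert-butyl)amino is expected to move this assay little, so a step that the limit leaves unreadable from compound 3 to compound 4 is expected without clear direction. Compound 4 is estimated at 1500 nM, within 400 nM to 6000 nM.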

Compound 4, half-maximal effective concentration: > 1000 nM
Compound 4: only a limit was reported (the forecaster's own chance of this, stated with the estimate: 60%); the middle value does not contradict the limit.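

In this assay, compound 4, like compound 3, gives only a limit and no number of its own: the limit of > 1000 nM in this assay, at which 2 of the 4 values shown sit.

The step between these two amides therefore cannot be read, so adding the amide hydrogen and the larger (tert-butyl)amino shows no measurable recovery, though any smaller change would stay hidden. Against the compounds with a fluorinated aryl group, the second amide also loses heavily, with an at least 13-fold higher number from compound 2 to compound 4 (1.14 log units; beyond the scatter), and an at least 11-fold higher number from compound 1 to compound 4 (1.06 log units; beyond the scatter).

Going by these compounds, it remains open how far above the limit either amide lies. A carboxylic acid or a plain primary amide at this place could show whether this chain can give a measurable value at all.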